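Trifluoromethyl for Methyl on the Carbonyl of Compound 2

The source may report more compounds than this note shows. Statements on the series, on what has been measured and on what is new or still open speak of the compounds shown alone.

Compound 1, `O=S(=O)(c1ccc(F)cc1)n1cc(CNCc2cccc(F)c2F)c2ccccc21`: 12400 nM
Compound 2, `CC(=O)N(Cc1cn(Cc2cccc(F)c2F)nn1)Cc1cn(S(=O)(=O)c2ccc(C)cc2)c2ccccc12`: 9100 nM
Compound 3, `CC(=O)N(Cc1cccc(F)c1F)Cc1cn(S(=O)(=O)c2ccc(C)cc2)c2ccccc12`: 17500 nM

Of the compounds shown here, three have been tested in a functional assay on 3T3-L1 cells (Mus musculus) for inhibition, with a stated time of 20 min; on this read-out higher numbers stand for weaker inhibition and lower numbers for stronger inhibition. Compound 2 gives the lowest of the three numbers, yet its gaps to compound 1 and to compound 3 both lie within the usual scatter, so no ranking among them can be claimed. Compound 4, `Cc1ccc(S(=O)(=O)n2cc(CN(Cc3cn(Cc4cccc(F)c4F)nn3)C(=O)C(F)(F)F)c3ccccc32)cc1`, differs from compound 2 in a single place: trifluoromethyl in place of methyl on a carbonyl carbon. Among the measured compounds shown here, no measured pair shows this same change, so its effect is not known from these data. The expected step is small, none beyond the scatter, a 1.0-fold lower number from compound 2 to compound 4 (0.00 log units; within the scatter). Compound 4 is therefore estimated to give 9000 nM, with a range from 3000 nM to 27000 nM.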

Compound 4, half-maximal inhibitory concentration: 19100 nM
Estimate against measurement, compound 4: 2.1-fold (0.33 log units) below, and the stated range covers the measured number.
By their numbers in this assay, from the lowest: compounds 2, 1, 3 and 4 (each within the scatter of the next, the first and the last beyond it).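

In this assay, trifluoromethyl in place of methyl on a carbonyl carbon gives a 2.1-fold higher number from compound 2 to compound 4 (0.32 log units; beyond the scatter), a modest step. Among the compounds shown here, this is the first pair differing in one place, and it shows that this position responds to the change, with weaker inhibition just beyond the usual scatter. No measurement shown here bears on the cause of this step.

As far as these compounds go, it remains open how an ethyl group, a longer chain or an amine on this carbonyl carbon would read. Also open, from the compounds shown here alone, is whether the same change on compound 3, which also carries an acetyl group, would give a similar step.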